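Prolyl Exchanged for Methionyl on a Sulfamoyl Adenosine

This account rests on a few compounds, and the source may have more. Where it says the series, first, only, none or still open, it means among the compounds named here.

Compound 2 `Nc1ncnc2c1ncn2[C@@H]1O[C@H](COS(=O)(=O)NC(=O)[C@@H]2CCCN2)[C@@H](O)[C@H]1O` and compound 1 `Nc1ncnc2c1ncn2[C@@H]1CO[C@H](COS(=O)(=O)NC(=O)[C@@H]2CCCN2)[C@@H](O)C1` share a common core joined through a sulfamoyl linker to an amino-acid residue. In a functional assay on PBMC cells (Homo sapiens) for inhibition (on this read-out higher numbers stand for weaker inhibition and lower numbers for stronger inhibition), compound 2 gives 700 nM, the lowest of the two numbers shown, while compound 1 gives 2800 nM, a gap beyond the usual scatter. Compound 3 `CSCC[C@H](N)C(=O)NS(=O)(=O)OC[C@H]1O[C@@H](n2cnc3c(N)ncnc32)[C@H](O)[C@@H]1O` carries 1-amino-3-(methylsulfanyl)propyl in place of pyrrolidin-2-yl on a carbonyl carbon. Among the compounds with values here, no measured pair shows this exchange, so the expectation rests on compound 2 alone. The step is expected to be modest, a slight loss: a 1.7-fold higher number from compound 2 to compound 3 (0.23 log units; within the scatter). Compound 3 is therefore estimated at 1200 nM, with a likely range from 250 nM to 6000 nM.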

Compound 3, half-maximal inhibitory concentration: 500 nM
The estimate for compound 3 lay 2.4-fold (0.38 log units) above the measured number; the measured number falls inside the stated range.
By their numbers in this assay, from the lowest: compounds 3 and 2 (each within the scatter of the next); then compound 1.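

In this assay, the exchange gives a 1.4-fold lower number from compound 2 to compound 3 (0.15 log units; within the scatter), so the number does not move beyond the scatter. On this carbonyl carbon, then, the ring of pyrrolidin-2-yl can be replaced by the open chain of 1-amino-3-(methylsulfanyl)propyl while the value stays within the scatter of compound 2. Nothing measured here bears on the reason for this result. As far as these compounds go, it remains open whether the sulfur matters, which an all-carbon chain such as butyl would test. From the compounds shown here alone, it also remains open whether the same exchange would behave alike on the core of compound 1.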